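Swapping the benzyl halogens on a pyrazole hydroxamate

The source may report more compounds than this note shows. Statements on the series, on what has been measured and on what is new or still open speak of the compounds shown alone.

The series shares one core, seen in compound 1 `O=C(NOCc1ccc(Cl)cc1Cl)c1cn(-c2ccccc2)nc1-c1ccccc1`, compound 2 `COc1ccc(-c2nn(-c3ccccc3)cc2C(=O)NOCc2ccccc2)cc1` and compound 3 `COc1ccc(-c2nn(-c3ccccc3)cc2C(=O)NOCc2ccccc2F)cc1`. In a functional assay on HeLa cells (Homo sapiens) for antiproliferative activity, read by MTT assay, with a stated time of 48 h, in the presence of a further agent that is not named here (a lower number here means a stronger inhibitor of growth, a higher number a weaker inhibitor of growth), compound 3 gives 2900 nM, the second highest of the three numbers. Its nearest neighbour is compound 2, which gives 2640 nM in this assay, and the single-point step a 1.1-fold higher number from compound 2 to compound 3 (0.04 log units; within the scatter) stays within the scatter. Among the measured compounds shown here, compound 1 gives 5100 nM in this assay, a number that also lies within the scatter of compound 3, though compound 1 differs from compound 3 in two places and no single step connects them.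

Compound 4 `COc1ccc(-c2nn(-c3ccccc3)cc2C(=O)NOCc2ccc(Cl)cc2Cl)cc1` carries the change (2,4-dichlorophenyl in place of 2-fluorophenyl on a saturated chain carbon bound to an oxygen). For the measured compounds named here, the only measured step at this position, from compound 2 to compound 3, was within the scatter, and the other compound bearing the 2,4-dichlorobenzyl group, compound 1, sits within the scatter of compound 3 as well. The step of a 1.3-fold higher number from compound 3 to compound 4 (0.12 log units; within the scatter) is therefore expected to be small. In this assay compound 4 is estimated at 3800 nM, with a plausible range from 1700 nM to 8500 nM.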

Compound 4, concentration for 50% growth inhibition: 5750 nM
The estimate for compound 4 lay 1.5-fold (0.18 log units) below the measured number; the range from low to high includes it.
By their numbers in this assay, from the lowest: compounds 2, 3, 1 and 4 (each within the scatter of the next, the first and the last beyond it).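

In this assay, among the compounds shown here, the change to the 2,4-dichlorobenzyl group produces the only step at this position that lies beyond the scatter: a 2.2-fold higher number from compound 2 to compound 4 (0.34 log units; beyond the scatter), a modest one, for 2,4-dichlorophenyl in place of phenyl. Against the 2-fluorophenyl group, the same position gives a 2.0-fold higher number from compound 3 to compound 4 (0.30 log units; within the scatter), which stays within the scatter, so the two halogenated benzyl groups are not told apart. With the 2,4-dichlorobenzyl group held fixed, the added methoxy group gives a 1.1-fold higher number from compound 1 to compound 4 (0.05 log units; within the scatter), also within the scatter, and nothing measured here accounts for any of these steps.

The compounds shown leave open whether a single chlorine on the benzyl ring would give a comparable step. They also do not show how an amine or a carboxylic acid on that ring, or a longer chain in place of the benzyl group, would behave.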